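Replacing the Hydroxyphenyl Arm of Compound 1 with Cyclopentyl

The source may hold more compounds than are shown below. What is called first, only, known or untested is meant among the compounds shown, and "the series" means these compounds.

Measured in a functional assay on HeLa cells (Homo sapiens) for cytotoxicity, read by WST assay, with a stated time of 48 h; a higher number here means a weaker inhibitor, a lower number a stronger inhibitor:

compound 1 `Oc1ccc(/C=C/C[C@H]2C[C@@H]([C@@H](O)c3ccccc3)CO[C@@H]2c2ccccc2)cc1` — 14400 nM
compound 2 `COc1cccc([C@H](O)[C@H]2CO[C@@H](c3ccc(OC)c(OC)c3)[C@H](C/C=C/c3ccc(OC)c(OC)c3)C2)c1` — 18600 nM
compound 3 `COc1ccc(/C=C/C[C@@H]2C[C@@H]([C@@H](O)c3ccc(OC)c(OC)c3)CO[C@H]2c2ccc(OC)c(OC)c2)cc1` — 17100 nM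

Compound 1 shows the lowest of these numbers, yet its gaps to compound 3 and to compound 2 both lie within the scatter, so no order among them can be read. Compound 4 `O[C@@H](c1ccccc1)[C@H]1CO[C@H](c2ccccc2)[C@@H](C/C=C/C2CCCC2)C1` differs from compound 1 by cyclopentyl in place of 4-hydroxyphenyl on a double-bonded chain carbon bound to a double-bonded chain carbon. For the measured compounds named here, no measured pair isolates this change, and the measured compounds vary at other places, so there is no step to lean on. The account therefore expects the step of a 1.3-fold higher number from compound 1 to compound 4 (0.10 log units; within the scatter) to stay within the scatter, with no clear direction. Compound 4 is estimated at 18000 nM, in a range from 7000 nM to 45000 nM.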

Compound 4, half-maximal inhibitory concentration: 9330 nM
For compound 4 the middle estimate is 1.9-fold (0.29 log units) above the measured one; the range from low to high includes it.
By their numbers in this assay, from the lowest: compounds 4, 1, 3 and 2 (each within the scatter of the next).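

In this assay, for the compounds shown here, the step of a 1.5-fold lower number from compound 1 to compound 4 (0.19 log units; within the scatter) gives the first reading at this position, as no earlier pair differed in one place only. The 4-hydroxyphenyl on this double-bonded chain carbon can give way to cyclopentyl, losing its aromatic ring and its hydrogen-bond donor and acceptor, without a change beyond the scatter. Nothing given here explains this result. From the compounds shown here alone, whether an amine or a carboxylic acid on this chain carbon would do the same remains open. So does whether the exchange would behave alike in compound 2 and compound 3, which carry methoxy groups.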